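The source may report more compounds than this note shows. Statements on the series, on what has been measured and on what is new or still open speak of the compounds shown alone.

Values in a physicochemical assay for solubility, read by spectrophotometry, in phosphate buffer, with a stated time of 18 h, at pH 7.4 (a higher number here means a more soluble compound, a lower number a less soluble compound), for the series:
- compound 1 `CCc1ccc(-c2nc3c(c(C)nn3-c3ccccc3)c(-c3ccccc3[N+](=O)[O-])c2C#N)cc1` gives 1200 nM
- compound 2 `CCc1ccc(-c2nc3c(c(C)nn3-c3ccccc3)c(-c3ccccc3I)c2C#N)cc1` gives 8500 nM
- compound 3 `CCc1ccc(-c2nc3c(c(C)nn3-c3ccccc3)c(-c3ccccc3C(F)(F)F)c2C#N)cc1` gives 11000 nM
- compound 4 `CCc1ccc(-c2nc3c(c(C)nn3-c3ccccc3)c(-c3cccc(O)c3)c2C#N)cc1` is not yet measured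

Compound 3 stands level with compound 2 within the scatter, as a 1.3-fold higher number from compound 2 to compound 3 (0.11 log units; within the scatter) shows, and clear of compound 1, as a 9.2-fold higher number from compound 1 to compound 3 (0.96 log units; beyond the scatter) shows.

The next change is 3-hydroxyphenyl in place of 2-(trifluoromethyl)phenyl on an aromatic carbon, with 3-hydroxyphenyl in place of 2-(trifluoromethyl)phenyl on an aromatic carbon, ortho to a cyano group. Three measured steps exchange a group on this same phenyl ring. Two are modest, a 7.1-fold higher number from compound 1 to compound 2 (0.85 log units; beyond the scatter) and a 9.2-fold higher number from compound 1 to compound 3 (0.96 log units; beyond the scatter), and the third, a 1.3-fold higher number from compound 2 to compound 3 (0.11 log units; within the scatter), lies within the scatter. For the measured compounds named here, no measured compound carries a 3-hydroxyphenyl group, so these steps guide the change only loosely. Compound 1 at 1200 nM shows that a modest step to a lower number remains possible here, so the range is kept wide. In this assay the expected step is a 1.2-fold lower number from compound 3 to compound 4 (0.09 log units; within the scatter), and no change beyond the scatter is expected. Compound 4 is estimated at 9000 nM, with an expected range of 2500 nM to 30000 nM.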

Compound 4, solubility: 18000 nM
Compound 4: middle estimate off by 2.0-fold (0.30 log units), on the low side, within the range that was stated.
By their numbers in this assay, from the lowest: compound 1; then compounds 2, 3 and 4 (each within the scatter of the next, the first and the last beyond it).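

The position ortho to a cyano group takes a 3-hydroxyphenyl group as readily as a 2-(trifluoromethyl)phenyl group: in this assay the exchange gives a 1.6-fold higher number from compound 3 to compound 4 (0.21 log units; within the scatter) and so supports no claim of a difference. Against 2-iodophenyl the same group gives a 2.1-fold higher number from compound 2 to compound 4 (0.33 log units; beyond the scatter) as a modest step, and against 2-nitrophenyl it gives a 15-fold higher number from compound 1 to compound 4 (1.18 log units; beyond the scatter) as the only large step at this position so far, leaving compound 1 alone at the low end. Nothing at hand bears on the cause of these steps.

Compound 4 changes both the substituent and its place on the phenyl ring, so the two effects cannot be separated here. Going by these compounds, a 2-hydroxyphenyl or 3-(trifluoromethyl)phenyl group would part them, and an amine or a carboxylic acid on this ring remains open.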